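The source may hold more compounds than are shown below. What is called first, only, known or untested is meant among the compounds shown, and "the series" means these compounds.

Of the compounds shown here, three of related build have been measured in a functional assay on L02 cells (Homo sapiens) for inhibition, read by Griess assay, with stated times of 1 h and 24 h; on this read-out higher numbers stand for weaker inhibition and lower numbers for stronger inhibition. Compound 1 `CCCc1nn(C)c2c(NC3CC3)nc(/C=C/c3nc(C)c(C)nc3C)nc12` gives 706000 nM there. Compound 2 `COc1cc(/C=C/c2nc(Cl)cc(NC(C)C)n2)cc(OC)c1OC` reaches only a limit of the method, < 40000 nM, as noted in the limit of < 40000 nM in this assay, at which 1 of the 3 values shown sits. Compound 3 `CC(C)Nc1nc(/C=C/c2ccccc2)nc2ccsc12` likewise stops at a limit, > 1000000 nM, described in the limit of > 1000000 nM in this assay, at which 1 of the 3 values shown sits, so among these three only compound 1 carries a true number. Compound 4 `COc1ccc(Nc2nc(/C=C/c3ccccc3)nc3ccsc23)cc1` differs from compound 3 in one place: 4-methoxyphenyl in place of isopropyl on a nitrogen on an aromatic ring. Among the measured compounds shown here, no measured pair shows this change, so the expectation rests on little. The step of an at least 3.3-fold lower number from compound 3 to compound 4 (0.52 log units; beyond the scatter) is expected to move toward stronger inhibition, though a limit may again be all that is reported. Compound 4 is expected to give 300000 nM, within 40000 nM to 1000000 nM.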

Compound 4, half-maximal inhibitory concentration: > 1000000 nM
Compound 4: no number, only a limit; the forecaster's own chance of this, stated with the estimate: 45%; middle value at least 3.3-fold (0.52 log units) from the limit.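

Among the compounds shown here, compound 3 and compound 4 both stop at the same limit, so no step between them can be read: the limit of > 1000000 nM in this assay, at which 2 of the 4 values shown sit.

The compounds shown leave open whether 4-methoxyphenyl in place of isopropyl changes inhibition at all in this assay.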